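Removing the pyrazole methyl: what to expect for compound 4

A few compounds are considered here, and "the series" means these few. Any claim that something is new, unique, unknown or untested is made for them only; others in the source may bear on it.

Compound 1 `O=C1NN=C(c2ccccc2)/C1=C/Nc1cc[nH]n1`: 74900 nM
Compound 2 `O=C1/C(=C\Nc2cc(-c3ccco3)[nH]n2)C(c2ccccc2)=NN1c1ccccc1`: 12400 nM
Compound 3 `Cc1cc(N/C=C2\C(=O)N(c3ccccc3)N=C2c2ccccc2)n[nH]1`: 10200 nM

In a functional assay on MDA-MB-453 cells (Homo sapiens) for antiproliferative activity, read by MTT assay, with a stated time of 72 h (on this read-out higher numbers stand for weaker inhibition and lower numbers for stronger inhibition), compound 3 gives the lowest of the three numbers, yet its neighbour compound 2 sits only a small distance away, within the scatter, while compound 1 is well beyond it. The change to compound 4 `O=C1/C(=C\Nc2cc[nH]n2)C(c2ccccc2)=NN1c1ccccc1` is hydrogen in place of methyl on an aromatic carbon. Going by the values given here, only one measured step touches the same ring: a 1.2-fold lower number from compound 2 to compound 3 (0.08 log units; within the scatter), which shows that swapping furan-2-yl for methyl on this pyrazole hardly moved the number. Compound 1 also bears an unsubstituted pyrazole, but it differs from compound 4 elsewhere as well, so its value does not isolate the effect of losing the methyl. Among the compounds with values here, with the one relevant step lying inside the scatter, the expectation is a small or no step, a 1.5-fold higher number from compound 3 to compound 4 (0.17 log units; within the scatter), with a modest lean toward a higher number once the methyl is gone. Compound 4 is therefore estimated at 15000 nM, within a range of 5000 nM to 45000 nM.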

Compound 4, half-maximal inhibitory concentration: 34700 nM
Beside the measured number, compound 4's estimate is 2.3-fold (0.36 log units) below it; the range from low to high includes it.
By their numbers in this assay, from the lowest: compounds 3 and 2 (each within the scatter of the next); then compound 4; then compound 1.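

In this assay this aromatic carbon turns out not to be indifferent: losing the methyl gives a 3.4-fold higher number from compound 3 to compound 4 (0.53 log units; beyond the scatter) and losing furan-2-yl gives a 2.8-fold higher number from compound 2 to compound 4 (0.45 log units; beyond the scatter) so either group, even the single carbon of methyl, goes with a lower number than hydrogen, while compound 2 and compound 3 stay within the scatter of each other. Compound 4 also gives a first one-place view of a second site: phenyl in place of hydrogen on the amide-type nitrogen in a ring gives a 2.2-fold lower number from compound 1 to compound 4 (0.33 log units; beyond the scatter) and so that site counts too. Nothing measured here says why these steps arise.

Going by these compounds, whether an amine, a carboxylic acid or a longer chain such as propyl on this aromatic carbon would lower the number further stays open. So does whether a benzyl group on the ring nitrogen would do more or less than phenyl.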